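The source may hold more compounds than are shown below. What is called first, only, known or untested is meant among the compounds shown, and "the series" means these compounds.

Measured so far:
- compound 1, `Cc1cnc(NC(=O)COc2ccc(/C=C3\SC(=O)NC3=O)cc2)s1`: in a functional assay on Gurav cells (Homo sapiens) for cytotoxicity, read by sulforhodamine B assay, with a stated time of 48 h (a lower number here means a stronger inhibitor of growth, a higher number a weaker inhibitor of growth), compound 1 gives 32400 nM; 195 nM (2 entries).
- compound 2, `O=C(COc1ccc(/C=C2\SC(=O)NC2=O)cc1)Nc1nc2ccccc2s1`: in this assay compound 2 gives < 100000 nM, which is a limit of the assay and not a number.

Compound 2 therefore has no single figure of its own in this assay; all that is known is that its result sits at the limit (the limit of < 100000 nM in this assay, at which 1 of the 2 values shown sits). Compound 1 returns two entries that lie far apart (the several entries of compound 1 in this assay, 32400 nM; 195 nM (2 entries)), so it offers no firm anchor either.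

Compound 3, `O=C(COc1ccc(/C=C2\SC(=O)NC2=O)cc1)Nc1ncc([N+](=O)[O-])s1`, has not yet been measured. It differs from compound 2 in one place: 5-nitro-1,3-thiazol-2-yl in place of 1,3-benzothiazol-2-yl on an amide-type nitrogen. The shared core and the amide-bearing side chain stay the same.

For the measured compounds named here, no step between measured compounds exists here, and with compound 2 at a limit and compound 1 scattered, no measured pair tells how large this change should be. The step that the limit leaves unreadable from compound 2 to compound 3 is expected to be modest and of uncertain direction, likely not clearly beyond the scatter. Compound 3 is expected at 20000 nM, within 2000 nM to 100000 nM.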

Compound 3, concentration for 50% growth inhibition: < 100000 nM
Compound 3: no number, only a limit; the forecaster's own chance of this, stated with the estimate: 30%; the middle value lies beyond the limit too.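

In this assay compound 3 gives < 100000 nM, which is a limit of the assay and not a number. For the compounds shown here, compound 2 also stands at a limit, so no step from compound 2 to compound 3 can be read. Still open, on these data alone, is whether 5-nitro-1,3-thiazol-2-yl in place of 1,3-benzothiazol-2-yl changes growth inhibition at all.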